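Working notes: aryl group swap on the ring amine

A few compounds are considered here, and "the series" means these few. Any claim that something is new, unique, unknown or untested is made for them only; others in the source may bear on it.

Measured so far:
compound 1, `c1coc(CNc2nc(NCCCN3CCCC3)nc3ccccc23)c1`: in a functional assay on HCT-116 cells (Homo sapiens) for cytotoxicity, read by MTT assay, with a stated time of 2 days, tested at 10 uM (a higher number here means more inhibition at the concentration tested (going by the name of the read-out), a lower number less inhibition), compound 1 gives 67.5%
compound 2, `Clc1cccc(N2CCN(CCCCNc3nc(NCc4ccco4)c4ccccc4n3)CC2)c1Cl`: in this assay compound 2 gives 94.7%

Compound 2 stands highest of the two numbers in this assay; compound 1 lies well below it, beyond the usual scatter, so the inhibition of compound 2 in this assay is the higher of the pair. Compound 3 `Cc1cccc(N2CCN(CCCCNc3nc(NCc4ccco4)c4ccccc4n3)CC2)c1C` differs from compound 2 in one place: 2,3-dimethylphenyl in place of 2,3-dichlorophenyl on an amine nitrogen in a ring. Among the measured compounds shown here, no measured pair covers this change, so the expected step of a number 8.7 percentage points lower from compound 2 to compound 3 (within the scatter) is judged small, downward or none beyond the scatter. Compound 3 is therefore estimated at 86%, with a range from 65% to 98%.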

Compound 3, a percentage reported as inhibition, at one concentration (the size of the read-out at that concentration, not a potency): 94.3%
Beside the measured number, compound 3's estimate is 8.3 percentage points below it, and the stated range covers the measured number.
By their numbers in this assay, from the lowest: compound 1; then compounds 3 and 2 (each within the scatter of the next).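

Putting 2,3-dimethylphenyl in place of 2,3-dichlorophenyl on the amine nitrogen in the ring gives a number 0.4 percentage points lower from compound 2 to compound 3 (within the scatter) in this assay, so this change leaves the read-out within the scatter. At this position, the two chlorine atoms are therefore not required for the inhibition seen at the concentration tested, at least when two methyl groups take their place. Nothing available bears on why these two groups read alike.

Going by these compounds, whether an unsubstituted phenyl, a pyridine ring or a cyclohexyl group on that nitrogen would read the same remains open. On these data alone, a read-out at one concentration also gives no potency, so any difference between compound 2 and compound 3 at other concentrations stays unknown.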